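The compounds below may be only part of what the source reports. "The series", "measured", "known", "first", "only" and "open" are said of these compounds alone.

The compounds share one core, seen in compound 3 `O=C1/C(=C\c2ccccc2Cl)c2ccccc2N1c1c(Cl)cccc1Cl`, and differ only in the aryl group on the double-bonded chain carbon bound to a double-bonded ring carbon. In a functional assay on B16-F10 cells (Homo sapiens) for cytotoxicity against B16-F10 (Mus musculus), read by MTT assay, with a stated time of 72 h (a higher number here means that more compound is needed for the effect, a lower number that less compound is needed), compound 3 gives 39 ug/mL. Compound 1 `O=C1/C(=C\c2ccc(F)cc2)c2ccccc2N1c1c(Cl)cccc1Cl` gives 38 ug/mL, and the two sit together, since a 1.0-fold higher number from compound 1 to compound 3 (0.01 log units; within the scatter). Compound 2 `COc1ccc(/C=C2\C(=O)N(c3c(Cl)cccc3Cl)c3ccccc32)cc1` reaches only a limit of the assay, reported as > 100 ug/mL, and not a number (the limit of > 100 ug/mL in this assay, at which 1 of the 3 values shown sits). Setting compound 2 against compound 3 gives an at least 2.5-fold lower number from compound 2 to compound 3 (0.40 log units; beyond the scatter).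

Compound 4 `O=C1/C(=C\c2ccc(Cl)cc2)c2ccccc2N1c1c(Cl)cccc1Cl` is not yet measured. It differs from compound 3 in one place: 4-chlorophenyl in place of 2-chlorophenyl on a double-bonded chain carbon bound to a double-bonded ring carbon.

Going by the values given here, two measured steps bear on this change. Swapping a 4-fluorophenyl for a 2-chlorophenyl made no difference worth the name, as a 1.0-fold higher number from compound 1 to compound 3 (0.01 log units; within the scatter) shows. Swapping a 4-methoxyphenyl for a 2-chlorophenyl gave an at least 2.5-fold lower number from compound 2 to compound 3 (0.40 log units; beyond the scatter), a change beyond the scatter. A 4-chlorophenyl resembles the 4-fluorophenyl of compound 1 more than the 4-methoxyphenyl of compound 2, so the expected step is a 1.2-fold lower number from compound 3 to compound 4 (0.09 log units; within the scatter), that is, none beyond the scatter. Compound 4 is therefore estimated at 32 ug/mL in this assay, with a range from 12 ug/mL to 85 ug/mL.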

Compound 4, concentration for half-maximal effect: > 100 ug/mL
Compound 4 gave a limit, no number; the forecaster's own chance of this, stated with the estimate: 10%; middle value at least 3.1-fold (0.49 log units) from the limit.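

The change gives an at least 2.5-fold higher number from compound 3 to compound 4 (0.40 log units; beyond the scatter), so at this position the placing of the chlorine on the phenyl group counts, and not only which atoms the group holds. The swap of chloro in place of fluoro on an aromatic carbon gives an at least 2.6-fold higher number from compound 1 to compound 4 (0.42 log units; beyond the scatter), so 4-chlorophenyl and 4-fluorophenyl, which might have been expected to behave alike, part ways in this assay, and compound 1 stands against any rule that a group named with a 4 here always gives a high number. Compound 2 and compound 4 both stand at a limit and not at a number, so the step between them cannot be read: the limit of > 100 ug/mL in this assay, at which 2 of the 4 values shown sit.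

Going by these compounds, what number compound 2 and compound 4 would give remains open, and so the steps to compound 4 are known only as minimum sizes. Also open is how the aryl group would fare if it carried an amine or a carboxylic acid, since the groups shown hold only fluoro, chloro or methoxy.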